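The source may hold more compounds than are shown below. What is called first, only, known or untested is meant among the compounds shown, and "the series" means these compounds.

In a functional assay on CCRF-CEM cells (Homo sapiens) for inhibition, read by sulforhodamine B assay, with a stated time of 48 h (on this read-out higher numbers stand for weaker inhibition of growth and lower numbers for stronger inhibition of growth), compound 1 `Cc1ccc(NC(=O)/C=C/c2ccccc2)c(C(N)=O)c1` reads 2360 nM while compound 2 `NC(=O)c1cc(Br)ccc1NC(=O)/C=C/c1ccccc1` reads 429 nM and compound 3 `NC(=O)c1cc(I)ccc1NC(=O)/C=C/c1ccccc1` reads 341 nM on the same scale. Two steps fix the place of the last of these: a 1.3-fold lower number from compound 2 to compound 3 (0.10 log units; within the scatter) lies within the scatter, and a 6.9-fold lower number from compound 1 to compound 3 (0.84 log units; beyond the scatter) lies beyond it. Compound 3 therefore shares the low end of the three numbers with compound 2.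

Compound 4 `NC(=O)c1cc(I)ccc1NC(=O)/C=C/c1ccccc1Cl` keeps all of compound 3 and makes one change (chloro in place of hydrogen on an aromatic carbon), chloro in place of hydrogen on an aromatic carbon, so that phenyl becomes 2-chlorophenyl.

The measured steps bear on this only loosely. Both a 5.5-fold lower number from compound 1 to compound 2 (0.74 log units; beyond the scatter) and a 6.9-fold lower number from compound 1 to compound 3 (0.84 log units; beyond the scatter) are modest, and both replace methyl at a different place. Within the data shown here, none of the measured compounds carries anything on the phenyl group, so the data offer no direction for this change. The best expectation is therefore no step beyond the scatter, although a modest step either way remains possible. The estimate amounts to an expected 1.1-fold lower number from compound 3 to compound 4 (0.06 log units; within the scatter) in this assay for this change. For compound 4 the expected value is 300 nM within an estimated range (100 nM to 900 nM).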

Compound 4, concentration for 50% growth inhibition: 484 nM
The estimate for compound 4 lay 1.6-fold (0.21 log units) below the measured number, within the range that was stated.
By their numbers in this assay, from the lowest: compounds 3, 2 and 4 (each within the scatter of the next); then compound 1.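

Among these compounds, compound 4 is the first compound here with anything on the phenyl group, and in this assay the step for chloro in place of hydrogen is a 1.4-fold higher number from compound 3 to compound 4 (0.15 log units; within the scatter), which lies within the scatter. A chloro on this aromatic carbon, ortho to a large group, therefore leaves compound 3 and compound 4 reading alike, so phenyl and 2-chlorophenyl cannot be ranked on this read-out, and the low numbers seen with iodo on the other ring are still present with the chloro in place. No measurement shown here offers an explanation for this result.

One chloro at one place says little about other groups on the phenyl group, since a methoxy, an amine or a carboxylic acid there, or a chloro elsewhere on that ring, could read quite differently. Going by these compounds, it also remains open whether 2-chlorophenyl would read the same way on the cores of compound 1 and compound 2, which carry methyl and bromo in place of iodo.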